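The source may hold more compounds than are shown below. What is called first, only, known or untested is meant among the compounds shown, and "the series" means these compounds.

For the measured compounds named here, compound 3 `Cc1ccc(CS/C(=C/c2c[nH]c3ccc(Cl)cc23)C(=O)c2ccc(Cl)cc2)cc1` gives 1000 nM in a functional assay on DU-145 cells (Homo sapiens) for inhibition, read by trypan blue exclusion, with a stated time of 96 h (a higher number here means a weaker inhibitor of growth, a lower number a stronger inhibitor of growth), and compound 1 `Cc1ccc(CS/C(=C/c2c[nH]c3ccc(Br)cc23)C(=O)c2ccc(Cl)cc2)cc1` gives 1000 nM; these two share the lowest of the three numbers so far, with no change at the digits printed from compound 1 to compound 3 (within the scatter) for chloro in place of bromo. Compound 2 `Cc1ccc(CS/C(=C/c2ccc(C)s2)C(=O)c2ccc(Cl)cc2)cc1` stands apart at 50000 nM.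

The next compound, compound 4 `Cc1ccc(CS/C(=C/c2cccc(Cl)c2Cl)C(=O)c2ccc(Cl)cc2)cc1`, carries 2,3-dichlorophenyl in place of 5-chloro-1H-indol-3-yl on a double-bonded chain carbon bound to a double-bonded chain carbon.

Going by the values given here, two measured steps bear on this place: a 50-fold higher number from compound 1 to compound 2 (1.70 log units; beyond the scatter) and a 50-fold lower number from compound 2 to compound 3 (1.70 log units; beyond the scatter). Both are large and both exchange an indolyl group with 5-methylthiophen-2-yl. Among the compounds with values here, no measured compound carries a phenyl group here, and a single non-indole comparison is thin evidence, so the size is uncertain. A rise beyond the scatter is still expected, possibly smaller than those two steps. The expected change is an 8.0-fold higher number from compound 3 to compound 4 (0.90 log units; beyond the scatter) in this assay. For compound 4 the estimate is 8000 nM, with an expected range of 1500 nM to 50000 nM.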

Compound 4, concentration for 50% growth inhibition: 25000 nM
The estimate for compound 4 lay 3.1-fold (0.49 log units) below the measured number; the range from low to high includes it.
By their numbers in this assay, from the lowest: compounds 1 and 3 (each within the scatter of the next); then compounds 4 and 2 (each within the scatter of the next).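

In this assay, a second non-indole group at this place also sits far from the indoles: a 25-fold higher number from compound 3 to compound 4 (1.40 log units; beyond the scatter), and a 25-fold higher number from compound 1 to compound 4 (1.40 log units; beyond the scatter). Against the other non-indole group the result is a 2.0-fold lower number from compound 2 to compound 4 (0.30 log units; within the scatter), so 2,3-dichlorophenyl and 5-methylthiophen-2-yl are not separated here, and the low numbers so far belong only to the 5-chloro-1H-indol-3-yl and 5-bromo-1H-indol-3-yl compounds. Nothing at hand accounts for this gap between the groups.

Still open, as far as these compounds go, is whether the low numbers depend on the two-ring indolyl group as a whole or on its hydrogen-bond donor, a question that a 1-methyl-1H-indol-3-yl group at this place would address. Also open, from the compounds shown here alone, is whether any single-ring group, such as an aminophenyl, can reach the indole level.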